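This account rests on a few compounds, and the source may have more. Where it says the series, first, only, none or still open, it means among the compounds named here.

Two members of the series have been measured in an ADME assay on PC-3 cells (Homo sapiens) for cytotoxicity, read by WST assay, tested at 100 uM; a lower number here means less inhibition, a higher number more inhibition at the concentration tested (going by the name of the read-out). Compound 1 `C=CCOc1cccc(NC(=O)C2CCCN(C(=O)c3cc(C(F)(F)F)cc(C(F)(F)F)c3)C2)c1` gives 0% in this assay, and compound 2 `CS(=O)(=O)Nc1cccc(C(=O)N2CCCC(C(=O)Nc3ccc(Cl)cc3)C2)c1` gives 3% in this assay; the two numbers lie within the scatter of each other, so neither stands apart from the other. Compound 3 `O=C(Nc1cccc(N2CCCC2=O)c1)C1CCCN(C(=O)c2cc(C(F)(F)F)cc(C(F)(F)F)c2)C1` shares the core of compound 1 and differs from it in one place: 2-oxopyrrolidin-1-yl in place of allyloxy on an aromatic carbon. Among the measured compounds shown here, no pair of measured compounds differs in a single place, so there is no measured step to anchor this change. Because compound 1 shows 0% and compound 2 shows 3%, both at the bottom of the read-out, the step in this assay is expected to be small and not beyond the scatter, in either direction. The step is expected to be a number 3 percentage points higher from compound 1 to compound 3 (within the scatter). For compound 3 the estimate in this assay is 3%, with a range from -8% to 15%.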

Compound 3, a percentage reported as inhibition, at one concentration (the size of the read-out at that concentration, not a potency): 0%
For compound 3 the middle estimate is 3 percentage points above the measured one, and the stated range covers the measured number.
By their numbers in this assay, from the lowest: compounds 1, 3 and 2 (each within the scatter of the next).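

Among the compounds shown here, the exchange of allyloxy for 2-oxopyrrolidin-1-yl on this aromatic carbon is the first single-place step, and in this assay it gives no change at the digits printed from compound 1 to compound 3 (within the scatter). At this position, meta to a large group, an open group of 4 heavy atoms and a five-membered non-aromatic ring of 6 heavy atoms therefore read alike, both at the bottom of the read-out. Nothing available explains this flat result or bears on it.

As far as these compounds go, whether an amine or a carboxylic acid at this position would lift the number off the bottom of the read-out remains open. So does whether the same exchange would read alike on a core other than that of compound 1.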